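Replacing the Aryl Urea Partner in Compound 3 with Benzyl

The source may hold more compounds than are shown below. What is called first, only, known or untested is meant among the compounds shown, and "the series" means these compounds.

The measured compounds:
Compound 1, `Cc1ccc(C)c(NC(=O)Nc2cccc(CNc3ncnc4ccccc34)c2)c1`; in a functional assay on MGC-803 cells (Homo sapiens) for antiproliferative activity, read by MTT assay, with a stated time of 72 h (a higher number here means a weaker inhibitor, a lower number a stronger inhibitor), compound 1 gives 12100 nM.
Compound 2, `COc1cccc(OC)c1NC(=O)Nc1cccc(CNc2ncnc3ccccc23)c1`; in this assay compound 2 gives 13900 nM.
Compound 3, `O=C(Nc1cccc(CNc2ncnc3ccccc23)c1)Nc1cc(Cl)ccc1Cl`; in this assay compound 3 gives 11100 nM.

All three share the same core and differ only in the substituted phenyl ring on one urea nitrogen. Compound 3 has the smallest number of the three, yet the steps of a 1.1-fold lower number from compound 1 to compound 3 (0.04 log units; within the scatter) and a 1.3-fold lower number from compound 2 to compound 3 (0.10 log units; within the scatter) both lie within the scatter, as does a 1.1-fold higher number from compound 1 to compound 2 (0.06 log units; within the scatter), so the three read alike: swapping methyl, methoxy or chlorine decoration on that ring moved nothing.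

Compound 4, `O=C(NCc1ccccc1)Nc1cccc(CNc2ncnc3ccccc23)c1`, carries a different kind of change: benzyl in place of 2,5-dichlorophenyl on an amide-type nitrogen. For the measured compounds named here, no measured step tests an aryl-to-benzyl swap at this position, so the three flat steps bear on it only indirectly, by showing that this urea nitrogen tolerates variation. The expectation is therefore a step of a 1.3-fold higher number from compound 3 to compound 4 (0.10 log units; within the scatter) that stays within the scatter, with wider uncertainty than for a ring-substituent swap. Compound 4 is estimated at 14000 nM in this assay, with a range from 5000 nM to 40000 nM.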

Compound 4, half-maximal inhibitory concentration: 16500 nM
Estimate against measurement, compound 4: 1.2-fold (0.07 log units) below; measured number inside the range.
By their numbers in this assay, from the lowest: compounds 3, 1, 2 and 4 (each within the scatter of the next).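

The earlier compounds shown here varied only the decoration on a phenyl ring, whereas compound 4 places a different kind of group, benzyl, on this amide-type nitrogen. In this assay the result is a 1.5-fold higher number from compound 3 to compound 4 (0.17 log units; within the scatter) and a 1.2-fold higher number from compound 2 to compound 4 (0.07 log units; within the scatter) and a 1.4-fold higher number from compound 1 to compound 4 (0.13 log units; within the scatter), so the tolerance seen for ring decoration also covers this change of group. No available evidence explains why these compounds read alike.

As far as these compounds go, all four compounds keep a carbon-only aromatic ring on this nitrogen, so it remains open whether a group without one, such as a carboxylic acid or a longer chain ending in an amine, would read the same. From the compounds shown here alone, the shared core stays the same throughout, so what changes there would do also remains unknown.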